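This account rests on a few compounds, and the source may have more. Where it says the series, first, only, none or still open, it means among the compounds named here.

Measured compounds:
Compound 1, `CCOC(=O)c1ccc(NC(=O)NCc2cocn2)cc1`: 27600 nM
Compound 2, `O=C(NCc1ccncc1)Nc1ccc(S(=O)(=O)c2cccc(Cl)c2)cc1`: 69 nM
Compound 3, `CCOC(=O)c1ccc(NC(=O)N(C)Cc2ccncc2)cc1`: a limit, > 100000 nM

All three were tested in an assay on isolated protein for activation of Nicotinamide phosphoribosyltransferase (Homo sapiens); on this read-out higher numbers stand for an effect only at larger amounts of compound and lower numbers for an effect already at smaller amounts. Of the two compounds that gave a number, compound 2 stands lowest; the nearest, compound 1, sits far higher, a gap well beyond the usual scatter, and the two differ in several parts of the structure at once, so that pair says nothing about any single change. Compound 3 reached only a limit of the assay, and (the limit of > 100000 nM in this assay, at which 1 of the 3 values shown sits).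

The unmeasured compound 4, `O=C(NCc1ccncc1)Nc1ccc(S(=O)(=O)c2ccccc2Cl)cc1`, keeps every atom of compound 2 but joins them differently: 2-chlorophenyl in place of 3-chlorophenyl on a sulfonyl sulfur. No pair of measured compounds differs in exactly this way, so the size of this step cannot be read from the numbers shown. A small step in this assay is expected, with no clear direction, most likely within the scatter or only a little beyond it. The estimated step from compound 2 to compound 4 is a 1.6-fold higher number from compound 2 to compound 4 (0.20 log units; within the scatter). Compound 4 is therefore estimated at 110 nM in this assay, with an expected range from 35 nM to 350 nM.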

Compound 4, half-maximal effective concentration: 79 nM
Compound 4: middle estimate off by 1.4-fold (0.14 log units), on the high side; the range from low to high includes it.
By their numbers in this assay, from the lowest: compounds 2 and 4 (each within the scatter of the next); then compound 1. At a limit, above all of these: compound 3.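

Among these compounds, compound 2 and compound 4 form the first pair here that differs in only one place, so a single change can finally be read in this assay: putting 2-chlorophenyl in place of 3-chlorophenyl on a sulfonyl sulfur gives a 1.1-fold higher number from compound 2 to compound 4 (0.06 log units; within the scatter). Among the compounds shown here, on this read-out the two chlorophenyl groups cannot be told apart at this position, something the earlier compounds, which differ from one another in several parts at once, could not show. Nothing measured here offers a reason for this result.

Still open, from the compounds shown here alone, is whether the position accepts groups of a different kind on the sulfonyl sulfur, such as a plain phenyl ring, a methyl group, or a phenyl ring carrying a carboxylic acid or an amine. The other steps between these compounds cannot be read, so it also remains unknown which of the several differences between compound 1 and compound 2 accounts for the wide gap in their numbers.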